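The source may hold more compounds than are shown below. What is called first, only, known or untested is meant among the compounds shown, and "the series" means these compounds.

Series notes. Going by the values given here, the three measured members share one core bearing a sulfonyl group and differ only in what that sulfonyl sulfur carries. Compound 1 `COCCN(C)S(=O)(=O)c1ccc(C)c(C#Cc2cc(Cl)ccc2OCC(=O)O)c1` gives 0.007 in an ADME assay on a cell-free system (plasma, Mus musculus); a higher number here means a larger unbound share of the compound, a lower number a smaller unbound share. Compound 2 `Cc1ccc(S(=O)(=O)NC(C)C)cc1C#Cc1cc(Cl)ccc1OCC(=O)O` gives 0.01 in this assay. Compound 3 `Cc1ccc(S(C)(=O)=O)cc1C#Cc1cc(Cl)ccc1OCC(=O)O` gives 0.027 in this assay, the highest of the three numbers. The steps of a 2.7-fold higher number from compound 2 to compound 3 (0.43 log units; beyond the scatter) and a 3.9-fold higher number from compound 1 to compound 3 (0.59 log units; beyond the scatter) are both beyond the scatter, whereas a 1.4-fold higher number from compound 1 to compound 2 (0.15 log units; within the scatter) lies within it.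

Compound 4 `Cc1ccc(S(=O)(=O)N(C)C)cc1C#Cc1cc(Cl)ccc1OCC(=O)O` has no result yet in this assay. It differs from compound 3 by dimethylamino in place of methyl on a sulfonyl sulfur. The two measured steps that bear on this are those in which methyl entered on the sulfonyl sulfur in place of an amino group, a 2.7-fold higher number from compound 2 to compound 3 (0.43 log units; beyond the scatter) and a 3.9-fold higher number from compound 1 to compound 3 (0.59 log units; beyond the scatter), and both went up. Compound 4 runs in the opposite direction, an amino group entering in place of methyl, so a decrease is expected. Dimethylamino is neither of the two amino groups measured, so the size of the step is uncertain; a modest decrease of about a 2.3-fold lower number from compound 3 to compound 4 (0.35 log units; beyond the scatter) in this assay is expected for compound 4. Compound 4 is therefore estimated at 0.012 in this assay, with a range of 0.006 to 0.025.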

Compound 4, unbound fraction: 0.01
The estimate for compound 4 lay 1.2-fold (0.08 log units) above the measured number; the range from low to high includes it.
By their numbers in this assay, from the lowest: compounds 1, 2 and 4 (each within the scatter of the next); then compound 3.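

In this assay, a third amino group on the sulfonyl sulfur confirms the separation from methyl in a direct exchange, a 2.7-fold lower number from compound 3 to compound 4 (0.43 log units; beyond the scatter), and dimethylamino does not stand apart from the other two amino groups, with no change at the digits printed from compound 2 to compound 4 (within the scatter) and a 1.4-fold higher number from compound 1 to compound 4 (0.15 log units; within the scatter). Isopropylamino, dimethylamino and (2-methoxyethyl)(methyl)amino therefore form one group within the scatter, so among these four compounds the differences between the amino groups do not register, while compound 3, with methyl on the sulfur, alone stands apart and no compound goes against this. Nothing available here accounts for this separation.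

On these data alone, whether the grouping extends to other amino groups remains open, for instance an unsubstituted amino group or one carrying a longer chain or a carboxylic acid. Methyl is also the only carbon group on the sulfur here, so it is unknown whether ethyl or a longer alkyl chain would stay with compound 3 or fall with the amino groups.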